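Swapping 2-Methoxyphenyl for 4-Hydroxyphenyl on the Amide

This account rests on a few compounds, and the source may have more. Where it says the series, first, only, none or still open, it means among the compounds named here.

Of the compounds shown here, three sharing one core have been tested in a functional assay on the whole organism for inhibition, with Rattus norvegicus as the target, read by paw edema, with stated times of 30 min and 3 h, at a dose of 0.28 mmol/kg by the oral route; a higher number here means more inhibition at the dose given (going by the name of the read-out), a lower number less inhibition. Compound 1 `COc1ccc(-n2nc(C(N)=O)nc2-c2cc(OC)c(OC)c(OC)c2)cc1` carries a free amide and gives 92%. Compound 2 `COc1ccc(-n2nc(C(=O)Nc3ccccc3OC)nc2-c2cc(OC)c(OC)c(OC)c2)cc1`, which bears a 2-methoxyphenyl on the amide nitrogen, gives 38%, the lowest of the three numbers. Compound 3 `COc1ccc(-n2nc(C(=O)Nc3ccc(C(F)(F)F)cc3)nc2-c2cc(OC)c(OC)c(OC)c2)cc1`, with a 4-(trifluoromethyl)phenyl in that position, gives 83%. The step of a number 54 percentage points lower from compound 1 to compound 2 (beyond the scatter) is large, whereas a number 9 percentage points lower from compound 1 to compound 3 (within the scatter) stays within the scatter, and a number 45 percentage points higher from compound 2 to compound 3 (beyond the scatter) is again large.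

Compound 4 `COc1ccc(-n2nc(C(=O)Nc3ccc(O)cc3)nc2-c2cc(OC)c(OC)c(OC)c2)cc1` differs from compound 2 in one place: 4-hydroxyphenyl in place of 2-methoxyphenyl on an amide-type nitrogen. Among the measured compounds shown here, the only measured step that exchanges one aryl group for another on this nitrogen is a number 45 percentage points higher from compound 2 to compound 3 (beyond the scatter), and it runs upward. For the measured compounds named here, no measured compound carries a 4-hydroxyphenyl there, so the size of the move remains uncertain, but the direction is expected to follow that step. Compound 4 is therefore expected to give 70%, with a range from 45% to 90%. The step expected here is a number 32 percentage points higher from compound 2 to compound 4 (beyond the scatter).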

Compound 4, a percentage reported as inhibition, in the whole organism at one dose (the size of the read-out at that dose, not a potency): 64%
Compound 4: the middle estimate sits 6 percentage points above what was measured, within the range that was stated.
By their numbers in this assay, from the lowest: compound 2; then compound 4; then compounds 3 and 1 (each within the scatter of the next).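

In this assay there is a number 26 percentage points higher from compound 2 to compound 4 (beyond the scatter) and also a number 19 percentage points lower from compound 3 to compound 4 (beyond the scatter), so on this amide-type nitrogen the outcome depends on which aryl group is present, and exchanging trifluoromethyl for hydroxy on an otherwise identical phenyl ring is enough to move the number beyond the scatter. Compound 3 had stayed within the scatter of the free amide, but the result here is a number 28 percentage points lower from compound 1 to compound 4 (beyond the scatter), which shows that placing a substituted phenyl on this nitrogen does not always leave the number level with compound 1. Nothing available explains these differences.

Compound 2 and compound 4 differ in both the group on the ring and its place on that ring, so the two contributions cannot be separated. A 4-methoxyphenyl would separate them, and a 4-aminophenyl would show whether another group can stand in for the hydroxy.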